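The compounds below may be only part of what the source reports. "The series", "measured", "known", "first", "only" and "open" are said of these compounds alone.

Compound 1 `S=C(N/N=C/c1ccc(Oc2ccc(Br)cc2)cc1)Nc1ccc(Cl)cc1` gives 6.37 in a physicochemical assay for lipophilicity, in phosphate buffer, measured as octanol-water partition, with a stated time of 24 h; on this read-out higher numbers stand for higher lipophilicity and lower numbers for lower lipophilicity.
Compound 2 `Fc1ccc(Oc2ccc(/C=N/NC(=S)Nc3ccccc3)cc2)cc1` gives 5.09 in this assay.
Compound 3 `S=C(N/N=C/c1ccc(Oc2ccc(Cl)cc2)cc1)Nc1ccc(Cl)cc1` gives 6.2 in this assay.

Compound 3 stands second highest of the three. Its nearest neighbour is compound 1, separated by a number 0.17 log units lower from compound 1 to compound 3 (within the scatter); compound 2 lies well below it, beyond the scatter. Compound 4 `Fc1ccc(Oc2ccc(/C=N/NC(=S)Nc3ccc(Cl)cc3)cc2)cc1` differs from compound 3 by fluoro in place of chloro on an aromatic carbon. Within the data shown here, the only measured step that bears on it is the halogen exchange a number 0.17 log units lower from compound 1 to compound 3 (within the scatter), which stayed within the scatter. Among the measured compounds shown here, no measured pair exchanges chloro for fluoro directly, and compound 2 differs from compound 4 in a second place as well, so it offers no clean comparison. A modest decrease in this assay is expected for compound 4, about a number 0.45 log units lower from compound 3 to compound 4 (beyond the scatter). Compound 4 is therefore estimated at 5.75, within a range from 5.35 to 6.15.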

Compound 4, partition coefficient: 5.84
Compound 4: middle estimate off by 0.09 log units, on the low side, within the range that was stated.
By their numbers in this assay, from the lowest: compound 2; then compound 4; then compounds 3 and 1 (each within the scatter of the next).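

Where chloro in place of bromo on this aromatic carbon stayed within the scatter, going on to fluoro at the same place does not in this assay (a number 0.36 log units lower from compound 3 to compound 4 (beyond the scatter)), and fluoro in place of bromo gives a step of the same direction (a number 0.53 log units lower from compound 1 to compound 4 (beyond the scatter)). Among these compounds, the first single-place reading for adding a chloro group also comes with this result (a number 0.75 log units higher from compound 2 to compound 4 (beyond the scatter)). Nothing available explains these steps. Open, on these data alone, is how an amine or a methoxy group would read at this place, and whether the fluoro step holds when the rest of the molecule carries no chloro.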